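A Sulfonamide Swapped for a Chlorothiophene Amide

A few compounds are considered here, and "the series" means these few. Any claim that something is new, unique, unknown or untested is made for them only; others in the source may bear on it.

Two compounds sharing one core were examined in an assay on isolated protein for inhibition of thiosulfate sulfurtransferase (Homo sapiens); on this read-out higher numbers stand for weaker inhibition and lower numbers for stronger inhibition. Compound 1 `O=S(=O)(Nc1ccc(-c2nc3cc(NS(=O)(=O)c4ccccc4)ccc3o2)cc1)c1ccccc1` bears phenylsulfonyl groups on its aromatic nitrogens; in this assay compound 1 reaches only the limit > 100000 nM. Compound 2 `COc1ccc(S(=O)(=O)Nc2ccc(-c3nc4cc(NS(=O)(=O)c5ccc(OC)cc5)ccc4o3)cc2)cc1` bears (4-methoxyphenyl)sulfonyl groups in the same places; in this assay compound 2 also reaches only the limit > 100000 nM. Compound 2 therefore stands exactly where both measured values sit, as the limit of > 100000 nM in this assay, at which 2 of the 2 values shown sit, records, and no number separates it from compound 1. Compound 3 `COc1ccc(S(=O)(=O)Nc2ccc3oc(-c4ccc(NC(=O)c5ccc(Cl)s5)cc4)nc3c2)cc1` differs from compound 2 in one place: (5-chlorothiophen-2-yl)carbonyl in place of (4-methoxyphenyl)sulfonyl on a nitrogen on an aromatic ring. No measured step of this kind exists among the compounds shown, so no direction can be drawn from them; the change expected here is an at least 1.2-fold lower number from compound 2 to compound 3 (0.09 log units; that floor lies within the scatter), which is none beyond the scatter. Compound 3 is estimated at 80000 nM, with a range from 10000 nM to 300000 nM.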

Compound 3, half-maximal inhibitory concentration: > 100000 nM
Compound 3: only a limit was reported; the forecaster's own chance of this, stated with the estimate: 60%; middle value at least 1.2-fold (0.09 log units) from the limit.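

No step can be read from compound 2 to compound 3, because both stand only as limits: the limit of > 100000 nM in this assay, at which 3 of the 3 values shown sit.

The compounds shown leave open what number any of them would reach in this assay, and whether (5-chlorothiophen-2-yl)carbonyl in place of (4-methoxyphenyl)sulfonyl changes that number at all.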